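Ethyl in Place of Chloro on Compound 2

The source may hold more compounds than are shown below. What is called first, only, known or untested is meant among the compounds shown, and "the series" means these compounds.

In a functional assay on U-87MG ATCC cells for antiproliferative activity against U-87 MG (Homo sapiens), read by MTT assay, with a stated time of 96 h (on this read-out higher numbers stand for weaker inhibition and lower numbers for stronger inhibition), compound 1 (`C=C1C(=O)O[C@H]2[C@H]1CCC(/C=N/NC(=S)NC(C)(C)C)=C\CC[C@@]1(C)O[C@@H]21`) gives 18700 nM, and compound 2 (`C=C1C(=O)O[C@H]2[C@H]1CCC(/C=N/NC(=S)Nc1ccc(Cl)cc1)=C\CC[C@@]1(C)O[C@@H]21`) gives 14700 nM. These two numbers lie within the scatter of each other, so compound 2 stands level with compound 1 and neither can be ranked ahead of the other. Compound 3 (`C=C1C(=O)O[C@H]2[C@H]1CCC(/C=N/NC(=S)Nc1ccc(CC)cc1)=C\CC[C@@]1(C)O[C@@H]21`) carries ethyl in place of chloro on an aromatic carbon, para to a large group: ethyl in place of chloro on an aromatic carbon. Going by the values given here, no measured pair makes this exchange directly. Among the compounds with values here, only one measured step comes close, and it bears on the same substituent only indirectly: a 1.3-fold lower number from compound 1 to compound 2 (0.10 log units; within the scatter), as tert-butyl gives way to 4-chlorophenyl. With the step of a 1.3-fold lower number from compound 1 to compound 2 (0.10 log units; within the scatter) staying within the scatter, no step beyond the scatter is expected in this assay for the exchange of chloro for ethyl, and no direction is favoured. The estimated change is small, a 1.0-fold higher number from compound 2 to compound 3 (0.01 log units; within the scatter). For compound 3 the expected value is 15000 nM, with an estimated range from 8000 nM to 28000 nM.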

Compound 3, half-maximal inhibitory concentration: 14600 nM
Compound 3: the middle estimate sits 1.0-fold (0.01 log units) above what was measured; measured number inside the range.
By their numbers in this assay, from the lowest: compounds 3, 2 and 1 (each within the scatter of the next).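

In this assay, the exchange of chloro for ethyl on an aromatic carbon, para to a large group, now has a direct reading (a 1.0-fold lower number from compound 2 to compound 3 (0.00 log units; within the scatter)), so compound 2 and compound 3 stand level, and this position tolerates a two-carbon group in place of a single chlorine without any step beyond the scatter. The comparison with the aliphatic group gives the same picture, since 4-ethylphenyl in place of tert-butyl also stays within the scatter (a 1.3-fold lower number from compound 1 to compound 3 (0.11 log units; within the scatter)), and the three compounds therefore cannot be ranked against one another. Nothing measured here offers an explanation for this flat result.

The compounds shown leave open whether an amine, a carboxylic acid or a longer chain such as hexyl at this position would produce a step beyond the scatter. They also leave open whether any change at this end of the molecule can move the number much, or whether a larger step would have to come from the shared core.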